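Hydroxy to Chloro: What to Expect for Compound 4

A few compounds are considered here, and "the series" means these few. Any claim that something is new, unique, unknown or untested is made for them only; others in the source may bear on it.

Measured compounds in the study:
compound 1 `O=C1/C(=C\c2cccc(Oc3ccccc3)c2)c2ccccc2N1c1c(Cl)cccc1Cl`: > 100 ug/mL
compound 2 `O=C1/C(=C\c2ccc(O)cc2)c2ccccc2N1c1c(Cl)cccc1Cl`: 2 ug/mL
compound 3 `Cc1ccc2nc(Cl)c(/C=C3\C(=O)N(c4c(Cl)cccc4Cl)c4ccccc43)cc2c1`: "not determined" (no result reported)

All three were examined in a functional assay on MIA PaCa-2 cells (Homo sapiens) for cytotoxicity, read by MTT assay, with a stated time of 72 h; a higher number here means that more compound is needed for the effect, a lower number that less compound is needed. Compound 2 stands alone as the only entry with an actual number, since it gives 2 ug/mL. The value shown for compound 1 is not a number but a limit of the assay, (the limit of > 100 ug/mL in this assay, at which 1 of the 3 values shown sits). Compound 3 was not determined, so it adds nothing to compare against. Within the data shown here, no pair of these measured compounds differs in only one place, so there is no measured step on which to lean.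

Compound 4 `O=C1/C(=C\c2ccc(Cl)cc2)c2ccccc2N1c1c(Cl)cccc1Cl` is the next compound to be tested. It differs from compound 2 by chloro in place of hydroxy on an aromatic carbon. Among the measured compounds shown here, with no measured step available, the expectation rests on the single number for compound 2 and on the nature of the change. A moderate loss of potency is expected, a step of a 4.0-fold higher number from compound 2 to compound 4 (0.60 log units; beyond the scatter) in this assay, though it could well stay within the usual scatter. Compound 4 is therefore expected to give about 8 ug/mL in this assay, most likely between 2 ug/mL and 40 ug/mL.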

Compound 4, concentration for half-maximal effect: 5 ug/mL
Compound 4: the middle estimate sits 1.6-fold (0.20 log units) above what was measured; measured number inside the range.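

Among these compounds, changing hydroxy to chloro on the aromatic carbon para to a large group gives a 2.5-fold higher number from compound 2 to compound 4 (0.40 log units; beyond the scatter) in this assay, the first measured step at this position. The step shows that the hydroxy group is not essential for activity here: compound 4, with 0 hydrogen-bond donors and 0 hydrogen-bond acceptors in the entering group, still gives a true number, 5 ug/mL, rather than a limit, although the modest step shows that the swap does change the result. Nothing shown here accounts for the size or direction of this step.

Going by these compounds, with only hydroxy and chloro compared at this position, it remains open how an amine, a methoxy group or a carboxylic acid in the same place would behave, and whether any of them would give a lower number than compound 2 or a higher one than compound 4. Among the compounds shown here, it also remains open whether the same swap would give a similar step on a different core, since this single pair is the only comparison available.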